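Replacing the Amino Group of a Low-Nanomolar Compound with Acetoxy

This account rests on a few compounds, and the source may have more. Where it says the series, first, only, none or still open, it means among the compounds named here.

Of the compounds shown here, three have been tested so far in a functional assay on Jurkat cells (Homo sapiens) for antiproliferative activity, read by MTT assay; a higher number here means a weaker inhibitor, a lower number a stronger inhibitor. Compound 1 `COc1ccc(/C=C2\CCc3cc(OC)c(OC)cc3C2=O)cc1` gives > 50000 nM, which is a limit of the assay and not a number. Compound 2 `COc1cc2c(cc1OC)C(=O)/C(=C/c1cc(F)cc(F)c1)C2` gives 19000 nM. Compound 3 `COc1cc2c(cc1OC)C(=O)/C(=C/c1cc(C)c(N)c(C)c1)C2` gives 55 nM, the lowest number of the set and well beyond the usual scatter from compound 2.

Compound 4 `COc1cc2c(cc1OC)C(=O)/C(=C/c1cc(C)c(OC(C)=O)c(C)c1)C2` has not yet been measured. It keeps the structure of compound 3 except for one group: acetoxy in place of amino on an aromatic carbon, ortho to two methyl groups and para to a large group (acetoxy in place of amino on an aromatic carbon). Among the measured compounds shown here, no measured pair in this set shows a swap of this kind, so any forecast rests on thin support.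

In this assay, a step towards weaker inhibition is expected, probably beyond the scatter but modest compared with the full spread of the set. That direction is favoured because compound 3 at 55 nM already sits at the low end, while the other two compounds lie far higher. The estimated step is a 5.5-fold higher number from compound 3 to compound 4 (0.74 log units; beyond the scatter). For compound 4, the expected value is 300 nM, with an estimated range of 50 nM to 2500 nM.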

Compound 4, half-maximal inhibitory concentration: 400 nM
Compound 4: middle estimate off by 1.3-fold (0.12 log units), on the low side; low and high end bracket the measured number.
By their numbers in this assay, from the lowest: compound 3; then compound 4; then compound 2. At a limit, above all of these: compound 1.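

In this assay, among the compounds shown here, putting acetoxy in place of amino gives a 7.3-fold higher number from compound 3 to compound 4 (0.86 log units; beyond the scatter) and is the first comparison in this set between two compounds that differ in one place only, so it shows directly that the number responds to the group on this aromatic carbon. The step is modest next to the change in the group itself: amino carries one hydrogen-bond donor and a single heavy atom, whereas acetoxy has four heavy atoms and no donor, yet compound 4 still gives 400 nM and so a donor at this place is not required for a reading at this level. Nothing measured here tells which part of the swap moves the number, and no available measurement bears on the reason for the step.

The swap alters size and hydrogen-bond donor count together, so the two remain tangled in this single pair. A hydroxyl group, which keeps a donor on oxygen, a methoxy group, which has none, or an acetamido group, which restores the nitrogen within a similar size, would each help to separate these changes at this position.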